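Benzyl Ether on the Shared Core: Expected Cytotoxicity

The compounds below may be only part of what the source reports. "The series", "measured", "known", "first", "only" and "open" are said of these compounds alone.

Compound 1, `Cc1ccc(S(=O)(=O)O[C@@H]2CO[C@H]3[C@@H]2OCc2nc4c(Br)c(C)c(Br)cc4n23)cc1`: 8940 nM
Compound 2, `O[C@@H]1CO[C@H]2[C@@H]1OCc1nc3cc(F)c(F)cc3n12`: 512000 nM
Compound 3, `Cc1c(Br)cc2nc3n(c2c1Br)[C@H]1OC[C@@H](O)[C@H]1OC3`: 250000 nM

Of the compounds shown here, three have been measured in an ADME assay on HEp-2 cells (Homo sapiens) for cytotoxicity, read by MTT assay, with a stated time of 60 h; a higher number here means that more compound is tolerated, a lower number that less compound is tolerated. Compound 3 stands second highest of the three numbers. Its nearest neighbour is compound 2, whose value in this assay, 512000 nM, lies higher by a gap that is beyond the scatter; its furthest neighbour is compound 1, whose value, 8940 nM, is far lower, also beyond the scatter. Compound 3 itself gives 250000 nM in this assay.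

Compound 4, `Cc1c(Br)cc2nc3n(c2c1Br)[C@H]1OC[C@@H](OCc2ccccc2)[C@H]1OC3`, has not yet been measured in this assay. It differs from compound 3 in one place: benzyl in place of hydrogen on an oxygen on a saturated carbon. Among the compounds with values here, no step between measured compounds covers this change. Compound 1, which carries a larger group on the corresponding oxygen, gives the lowest number of the three, so a step downward beyond the scatter is expected. For compound 4 the expected value in this assay is 60000 nM, with a range from 15000 nM to 250000 nM, meaning an expected step of a 4.2-fold lower number from compound 3 to compound 4 (0.62 log units; beyond the scatter).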

Compound 4, half-maximal cytotoxic concentration: 115000 nM
Compound 4: the middle estimate sits 1.9-fold (0.28 log units) below what was measured; low and high end bracket the measured number.
By their numbers in this assay, from the lowest: compound 1; then compound 4; then compound 3; then compound 2.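

Within the data shown here, putting benzyl in place of hydrogen on this oxygen gives the first direct reading of a change at this position: in this assay the step is a 2.2-fold lower number from compound 3 to compound 4 (0.34 log units; beyond the scatter) and counts as modest. Compound 4 still stands well above compound 1 at 8940 nM on the same core, so a benzyl group on this oxygen does not bring the number down to the level seen with the larger group of compound 1. Nothing measured here gives a reason for the step.

The compounds shown leave open whether a shorter ether such as methoxy, or an amine or a carboxylic acid on the benzyl ring, would move the number further. They also leave open whether the same change would give a similar step on the core of compound 2.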